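Quinoline thiosemicarbazones: aryl versus dimethyl on the thioamide nitrogen

The source may hold more compounds than are shown below. What is called first, only, known or untested is meant among the compounds shown, and "the series" means these compounds.

Measured so far:
- Compound 1, `COc1ccc(C)cc1NC(=S)N/N=C/c1ccc2ccccc2n1`: in a functional assay on HT-29 cells (Homo sapiens) for antiproliferative activity, read by sulforhodamine B assay, with a stated time of 72 h (on this read-out lower numbers stand for stronger inhibition and higher numbers for weaker inhibition), compound 1 sits at the limit of > 100000 nM, which is a limit and not a number.
- Compound 2, `Cc1ccccc1NC(=S)N/N=C/c1ccc2ccccc2n1`: in this assay compound 2 gives 42300 nM.
- Compound 3, `CN(C)C(=S)N/N=C/c1ccc2ccccc2n1`: in this assay compound 3 gives 20 nM.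

Among the two numbers available, compound 2 stands highest; its nearest neighbour is compound 3, far below it and well beyond the scatter. Compound 1 sits at the limit (the limit of > 100000 nM in this assay, at which 1 of the 3 values shown sits). The shared core is carried unchanged through all three; the difference lies only in what sits on the amide-type nitrogen.

Compound 4, `Fc1ccc(NC(=S)N/N=C/c2ccc3ccccc3n2)cc1`, is not yet measured. Relative to compound 2 the change is 4-fluorophenyl in place of 2-methylphenyl on an amide-type nitrogen. Going by the values given here, both aryl-bearing compounds so far are weak, while only compound 3 is potent, so a 4-fluorophenyl is expected to stay near compound 2 rather than move toward compound 3. The expected step in this assay from compound 2 to compound 4 is a 1.2-fold lower number from compound 2 to compound 4 (0.08 log units; within the scatter), small and within the scatter. Compound 4 is therefore estimated at 35000 nM, with a range from 8000 nM to 100000 nM.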

Compound 4, half-maximal inhibitory concentration: 28500 nM
The estimate for compound 4 lay 1.2-fold (0.09 log units) above the measured number, within the range that was stated.
By their numbers in this assay, from the lowest: compound 3; then compounds 4 and 2 (each within the scatter of the next). At a limit, above all of these: compound 1.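

Going by these compounds alone, the change to 4-fluorophenyl in place of 2-methylphenyl on the amide-type nitrogen gives a 1.5-fold lower number from compound 2 to compound 4 (0.17 log units; within the scatter) in this assay, the first comparison in which only the aryl group differs. This swap therefore does not separate the two aryl compounds, and neither comes close to compound 3, which gives 20 nM in the same assay. Nothing measured here accounts for how these two aryl groups read.

Still open, going by these compounds, is whether a single methyl on this nitrogen, with the hydrogen kept, or a ring amine such as morpholine in place of the two methyl groups, stays nearer compound 3 or nearer the aryl compounds. Also open, on these data alone, is whether an amine or a carboxylic acid on the phenyl ring would move the aryl compounds at all.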